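Trifluoromethyl in place of the ester on an aziridine urea

A few compounds are considered here, and "the series" means these few. Any claim that something is new, unique, unknown or untested is made for them only; others in the source may bear on it.

Compound 1, `CCOC(=O)c1ccc(NC(=O)N2CC2C#N)cc1`: 5800 nM
Compound 2, `N#CC1CN1C(=O)Nc1ccc(Cl)cc1Cl`: a limit, > 39000 nM
Compound 3, `N#CC1CN1C(=O)Nc1cccnc1`: 12000 nM

The three measured compounds share the core of compound 1 and differ only in the aromatic part. In a functional assay on A-375 cells (Homo sapiens) for inhibition (a lower number here means a stronger inhibitor, a higher number a weaker inhibitor), compound 1 gives 5800 nM, the lowest of the two numbers shown. Compound 3 gives 12000 nM, a gap beyond the usual scatter. Compound 2 reaches only (the limit of > 39000 nM in this assay, at which 1 of the 3 values shown sits), a limit rather than a number.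

Compound 4, `N#CC1CN1C(=O)Nc1ccc(C(F)(F)F)cc1`, has not yet been measured. It differs from compound 1 by trifluoromethyl in place of ethoxycarbonyl on an aromatic carbon. Going by the values given here, no step between measured compounds covers this change, so a modest step is expected in this assay, a 1.4-fold higher number from compound 1 to compound 4 (0.14 log units; within the scatter), toward a similar or slightly weaker value. Compound 4 is thus estimated at 8000 nM, within a range from 3000 nM to 25000 nM.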

Compound 4, half-maximal inhibitory concentration: 11800 nM
Beside the measured number, compound 4's estimate is 1.5-fold (0.17 log units) below it, within the range that was stated.
By their numbers in this assay, from the lowest: compound 1; then compounds 4 and 3 (each within the scatter of the next). At a limit, above all of these: compound 2.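

The earlier compounds shown here offered no step at any position; this one gives the first, on the aromatic carbon para to a group of 8 heavy atoms, where in this assay trifluoromethyl in place of ethoxycarbonyl gives a 2.0-fold higher number from compound 1 to compound 4 (0.31 log units; beyond the scatter). The group that leaves carries hydrogen-bond acceptors and the one that enters carries none, yet compound 4 still gives a measured number, 11800 nM. Nothing shown explains this step.

A single change cannot show how far this position tolerates other groups. On these data alone, whether a carboxylic acid, an amine or a longer alkyl chain there would give a lower or higher number remains open.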